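The source may hold more compounds than are shown below. What is called first, only, known or untested is meant among the compounds shown, and "the series" means these compounds.

Compound 1 `CC1=CC[C@@H]([C@@](C)(O)CCCC(C)(C)NC=S)CC1`: 42500 nM
Compound 2 `CC1=CC[C@@H]([C@@](C)(O)CCCC(C)(C)NC(=S)N/N=C\c2ccc(O)cc2)CC1`: 40100 nM
Compound 3 `CC1=CC[C@@H]([C@@](C)(O)CCCC(C)(C)NC(=S)N/N=C\c2ccc([N+](=O)[O-])cc2)CC1`: 62200 nM

In a functional assay on UACC-62 cells (Homo sapiens) for cytotoxicity, read by sulforhodamine B assay (on this read-out lower numbers stand for stronger inhibition of growth and higher numbers for weaker inhibition of growth), compound 2 gives 40100 nM, and none of the three numbers is separated from it beyond the scatter: compound 1 gives 42500 nM, and the step of a 1.6-fold higher number from compound 2 to compound 3 (0.19 log units; within the scatter) is also within the scatter. Compound 4 `CC1=CC[C@@H]([C@@](C)(O)CCCC(C)(C)NC(=S)N/N=C\c2ccccc2Cl)CC1` differs from compound 2 by 2-chlorophenyl in place of 4-hydroxyphenyl on a carbon with a double bond to nitrogen. Among the compounds with values here, the only measured step that bears on this change is the exchange on the same aromatic ring, a 1.6-fold higher number from compound 2 to compound 3 (0.19 log units; within the scatter), which stayed within the scatter. On that basis no step beyond the scatter in this assay is expected. Compound 4 is therefore estimated at 45000 nM, with a range from 20000 nM to 100000 nM. This estimate means the expected step of a 1.1-fold higher number from compound 2 to compound 4 (0.05 log units; within the scatter).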

Compound 4, concentration for total growth inhibition: > 100000 nM
Compound 4 gave a limit, no number; the forecaster's own chance of this, stated with the estimate: 10%; at least 2.2-fold (0.34 log units) between middle value and limit.
By their numbers in this assay, from the lowest: compounds 2, 1 and 3 (each within the scatter of the next). At a limit, above all of these: compound 4.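

In this assay compound 4 gives > 100000 nM, which is a limit and not a number. Within the data shown here, the exchange on a carbon with a double bond to nitrogen can therefore shift this read-out: 2-chlorophenyl in place of 4-hydroxyphenyl gives an at least 2.4-fold higher number from compound 2 to compound 4 (0.39 log units; beyond the scatter), the only step here beyond the scatter. Against the 4-nitrophenyl group the result is less firm, with an at least 1.6-fold higher number from compound 3 to compound 4 (0.20 log units; that floor lies within the scatter).

As far as these compounds go, what a 4-chlorophenyl or an unsubstituted phenyl group would give at this place remains open. The compounds shown therefore do not separate the entry of the chlorine, its place on the ring and the departure of the hydroxy group.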